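Swapping the dimethylamino ring of compound 2

The compounds below may be only part of what the source reports. "The series", "measured", "known", "first", "only" and "open" are said of these compounds alone.

In a functional assay on DU-145 cells (Homo sapiens) for inhibition, read by trypan blue exclusion, with a stated time of 96 h (on this read-out lower numbers stand for stronger inhibition of growth and higher numbers for weaker inhibition of growth), compound 1 `O=C(/C(=C\c1ccc(Br)cc1)Sc1ccccc1Br)c1ccc(Br)cc1` gives 1000 nM. Compound 2 `CN(C)c1ccc(/C=C(/Sc2ccccc2Br)C(=O)c2ccc(Br)cc2)cc1` gives > 100000 nM, which is a limit of the assay and not a number. Compound 2 therefore stands at the weak end of the two results, with no exact value. Compound 3 `O=C(/C(=C\c1ccccc1O)Sc1ccccc1Br)c1ccc(Br)cc1` carries 2-hydroxyphenyl in place of 4-(dimethylamino)phenyl on a double-bonded chain carbon bound to a double-bonded chain carbon. Among the compounds with values here, one measured step bears on this change, and it is large: an at least 100-fold higher number from compound 1 to compound 2 (2.00 log units; beyond the scatter). That step brought in the dimethylamino group, which compound 3 no longer has, so much of the lost inhibition may return. Within the data shown here, no measured compound carries a hydroxy group, so the range stays wide. The estimated change is an at least 20-fold lower number from compound 2 to compound 3 (1.30 log units; beyond the scatter), a large step toward stronger inhibition of growth. For compound 3 the expected value is 5000 nM, within an estimated range of 700 nM to 40000 nM.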

Compound 3, concentration for 50% growth inhibition: 50000 nM
Compound 3: the middle estimate sits 10-fold (1.00 log units) below what was measured; measured number above the stated range.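

Dropping the dimethylamino group is not enough to bring back growth inhibition at this place: with 2-hydroxyphenyl in place of 4-bromophenyl on the double-bonded chain carbon, the result is a 50-fold higher number from compound 1 to compound 3 (1.70 log units; beyond the scatter). Against the dimethylamino ring, the change shows only an at least 2.0-fold lower number from compound 2 to compound 3 (0.30 log units; that floor lies within the scatter), so no real gain can be claimed. The true size of this step cannot be read because compound 2 has a limit and not a number: the limit of > 100000 nM in this assay, at which 1 of the 3 values shown sits.

Still open, going by these compounds, is whether the bromo group itself matters for the stronger inhibition seen with compound 1, or whether other groups on that ring would serve as well. A plain phenyl ring, or a ring bearing a chloro or methoxy group at this place, would help to answer that.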